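The source may report more compounds than this note shows. Statements on the series, on what has been measured and on what is new or still open speak of the compounds shown alone.

In an assay on HL-60 cells for agonist activity at N-formyl peptide receptor 3 (Homo sapiens), read by calcium flux (on this read-out lower numbers stand for an effect already at smaller amounts and higher numbers for an effect only at larger amounts of compound), compound 2 `Cc1cc(Cc2cccc(Cl)c2)c(=O)n(CC(=O)Nc2ccc(Br)cc2)n1` gives only a limit, > 50000 nM, and not a number. Compound 1 `COc1cccc(Cc2cc(C3CCCCC3)nn(CC(=O)Nc3ccc(Br)cc3)c2=O)c1` likewise gives only a limit in this assay, > 50000 nM. Compound 3 `Cc1cc(Cc2cccc(Br)c2)c(=O)n(CC(=O)Nc2ccc(Br)cc2)n1` is also recorded only as a limit in this assay, > 50000 nM. So every measured value sits together: the limit of > 50000 nM in this assay, at which 3 of the 3 values shown sit. The single change among these compounds that differs in one place, bromo in place of chloro on an aromatic carbon, yields a step that the two limits leave unreadable from compound 2 to compound 3. Compound 4 `Cc1cc(Cc2ccc(C(N)=O)cc2)c(=O)n(CC(=O)Nc2ccc(Br)cc2)n1` differs from compound 2 by 4-carbamoylphenyl in place of 3-chlorophenyl on a saturated chain carbon bound to an aromatic carbon. Among the measured compounds shown here, no measured step touches this change, and the measured steps give no readable size in this assay, so neither a direction nor a size beyond the scatter can be drawn from them. Compound 4 is therefore expected to remain where the measured compounds sit, most probably again as a limit rather than a number. The estimated step from compound 2 to compound 4 is a step that the limit leaves unreadable from compound 2 to compound 4. For compound 4 the estimate in this assay is 60000 nM, with a range from 8000 nM to 300000 nM.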

Compound 4, half-maximal effective concentration: > 50000 nM
Compound 4 was reported as a limit; the forecaster's own chance of this, stated with the estimate: 75%; the middle value does not contradict the limit.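

Compound 4 gives only a limit, so the steps to it from compound 2 and from compound 3 cannot be read, and all the compounds stay together: the limit of > 50000 nM in this assay, at which 4 of the 4 values shown sit. The compounds shown leave open which change, if any, would give a real number in this assay.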